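The source may hold more compounds than are shown below. What is called first, only, known or untested is meant among the compounds shown, and "the series" means these compounds.

Measured so far:
Compound 1 `CC1(c2ccccc2)CC(=O)N(CC(=O)N2CCN(c3ccccc3F)CC2)C1=O` gives "not active" (no number reported).
Compound 2 `COc1cccc(N2CCN(C(=O)CN3C(=O)CC(C)(c4ccccc4)C3=O)CC2)c1` gives "not active" (no number reported).
Compound 3 `CC1(c2ccccc2)CC(=O)N(CC(=O)N2CCC(Cc3ccccc3)CC2)C1=O` gives 300 mg/kg.

All three share one core and differ only in the group attached at the far end of the amide. They were tested in a functional assay on the whole organism (strain CD-1) with Mus musculus as the target, in the maximal electroshock model, with a stated time of 2 h; on this read-out lower numbers stand for an effect already at smaller amounts and higher numbers for an effect only at larger amounts of compound. Among the compounds with values here, compound 2 stands without a single number on this read-out; its entry is "not active" (no number reported), and compound 1 is the one other compound in the set that likewise has no number. Only compound 3 yields a figure, 300 mg/kg, which is a large amount of compound.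

The step to compound 4 `CC1(c2ccccc2)CC(=O)N(CC(=O)N2CCN(c3ccc(F)cc3)CC2)C1=O` changes a single group: 4-fluorophenyl in place of 3-methoxyphenyl on an amine nitrogen in a ring. Within the data shown here, no step between two measured compounds matches this change, so its size and direction cannot be read from the data. The expectation is that compound 4 will most likely again report no effect because compound 2 gives "not active" (no number reported), and that if a number does appear it will be a high one. Compound 4 is thus estimated at about 300 mg/kg, within a range from 100 mg/kg to 1000 mg/kg.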

Compound 4, minimum effective dose: 100 mg/kg
Estimate against measurement, compound 4: 3.0-fold (0.48 log units) above, within the range that was stated.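

Within the data shown here, compound 2 gives "not active" (no number reported) and so offers no number to set against compound 4, which means no step between these two compounds can be read. The compounds shown leave open how far replacing 3-methoxyphenyl with 4-fluorophenyl shifts the dose needed in this assay. No measured evidence here bears on this result.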